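This account rests on a few compounds, and the source may have more. Where it says the series, first, only, none or still open, it means among the compounds named here.

Of the compounds shown here, three built on a shared core have been measured in a functional assay on P388 cells (Mus musculus) for cytotoxicity; a higher number here means a weaker inhibitor, a lower number a stronger inhibitor. Compound 3 `Cc1cc(-c2c(F)cc3c(=O)c(Cc4c(O)cc(O)cc4O)cn(C4CC4)c3c2F)cc(C)n1` gives 470 nM and compound 1 `Cc1cc(-c2c(F)cc3c(=O)c(Cc4ccccc4O)cn(C4CC4)c3c2F)cc(C)n1` gives 670 nM, so these two share the low end of the numbers. Compound 2 `COc1ccccc1Cc1cn(C2CC2)c2c(F)c(-c3cc(C)nc(C)c3)c(F)cc2c1=O` stands far off at 37000 nM.

Compound 4 `Cc1cc(-c2c(F)cc3c(=O)c(Cc4ccc(O)cc4)cn(C4CC4)c3c2F)cc(C)n1`, still unmeasured, differs from compound 3 on a saturated chain carbon bound to an aromatic carbon: 4-hydroxyphenyl in place of 2,4,6-trihydroxyphenyl on a saturated chain carbon bound to an aromatic carbon.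

Among the compounds with values here, two measured steps bear on this change. Replacing 2-hydroxyphenyl with 2,4,6-trihydroxyphenyl gave a 1.4-fold lower number from compound 1 to compound 3 (0.15 log units; within the scatter), which is no real shift. Within the data shown here, putting a methyl in place of the hydrogen on the oxygen gave a 55-fold higher number from compound 1 to compound 2 (1.74 log units; beyond the scatter), a large rise, and compound 2 is the only measured compound without a free hydroxy group. Compound 4 keeps a free hydroxy group, so a jump of that size is not expected. However, the 4-hydroxyphenyl group has not been measured alone on this core, and the data cannot show how much the place of the hydroxy group matters. A modest move toward a higher number in this assay is therefore expected, and the expected step is a 3.2-fold higher number from compound 3 to compound 4 (0.50 log units; beyond the scatter). For compound 4 the estimated value is 1500 nM, with an expected range from 400 nM to 8000 nM.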

Compound 4, half-maximal inhibitory concentration: 1500 nM
Beside the measured number, compound 4's estimate shows no gap at the digits printed, within the range that was stated.
By their numbers in this assay, from the lowest: compounds 3 and 1 (each within the scatter of the next); then compound 4; then compound 2.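

Moving the single hydroxy group, from 2-hydroxyphenyl to 4-hydroxyphenyl, gives a 2.2-fold higher number from compound 1 to compound 4 (0.35 log units; beyond the scatter) in this assay, so the two groups are not interchangeable at this position, though the difference is modest. The change from 2,4,6-trihydroxyphenyl to 4-hydroxyphenyl gives a similar modest rise, a 3.2-fold higher number from compound 3 to compound 4 (0.50 log units; beyond the scatter), whereas the earlier change from 2-hydroxyphenyl to 2,4,6-trihydroxyphenyl stayed within the scatter, so the effect of altering the hydroxy groups depends on which ones remain. Compound 4 still sits far from the methyl-capped compound, with a 25-fold lower number from compound 2 to compound 4 (1.39 log units; beyond the scatter), which shows that a free hydroxy group in a different place on the ring retains most of what compound 2 lacks.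

The data offer no independent measurement that accounts for these shifts. Within the data shown here, still open are how a 4-methoxyphenyl group would compare with 4-hydroxyphenyl, which would show whether capping this hydroxy group costs as much as capping the one in compound 1, and how an amine, a carboxylic acid or a longer chain would fare on this saturated chain carbon.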